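The source may report more compounds than this note shows. Statements on the series, on what has been measured and on what is new or still open speak of the compounds shown alone.

Measured compounds:
compound 1 `Cc1ccccc1-n1cc(-c2ccc(NS(=O)(=O)c3c[nH]c(=O)[nH]c3=O)cc2)nn1`: "not toxic" (no number reported)
compound 2 `O=c1[nH]cc(S(=O)(=O)Nc2ccc(-c3cn(-c4ccccc4Cl)nn3)cc2)c(=O)[nH]1`: 19300 nM

Going by the values given here, in an ADME assay on L02 cells (Homo sapiens) for cytotoxicity, read by MTT assay, with a stated time of 24 h (on this read-out lower numbers stand for higher toxicity in this test and higher numbers for lower toxicity in this test), compound 2 is the only entry with a number. Among the compounds with values here, compound 1 is reported there only as "not toxic" (no number reported), without a value, so no step between measured compounds can be counted. On the numbers shown, compound 2 stands alone at 19300 nM.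

Compound 3 `O=c1[nH]cc(S(=O)(=O)Nc2ccc(-c3cn(-c4ccc(Cl)cc4)nn3)cc2)c(=O)[nH]1` is the unmeasured member. It differs from compound 2 only in the ring on the aromatic nitrogen: 4-chlorophenyl in place of 2-chlorophenyl on an aromatic nitrogen; the two have the same atoms, joined differently. Within the data shown here, with no measured pair to guide the size of such a step, the expectation is no change beyond the usual scatter, in either direction. Compound 3 is therefore estimated at 19000 nM, range 8000 nM to 45000 nM. The expected step of a 1.0-fold lower number from compound 2 to compound 3 (0.01 log units; within the scatter) is within the scatter.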

Compound 3, half-maximal cytotoxic concentration: 42900 nM
Beside the measured number, compound 3's estimate is 2.3-fold (0.35 log units) below it, within the range that was stated.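

In this assay, going by these compounds alone, the exchange of 2-chlorophenyl for 4-chlorophenyl on the aromatic nitrogen gives a 2.2-fold higher number from compound 2 to compound 3 (0.35 log units; beyond the scatter) as the first step that can be read. It shows that the read-out at this position responds to where the chlorine sits on the phenyl ring, although the atoms stay the same and the step is modest. The higher number marks compound 3 as the less toxic of this pair in this test, and nothing available bears on the reason for the step.

Compound 1 gives "not toxic" (no number reported) and so cannot be placed against either number. Still open, as far as these compounds go, is how the read-out would respond to an amine or a carboxylic acid in place of the chlorine on the phenyl ring.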